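Cyano in Place of Fluoro: Compound 3 to Compound 4

The source may report more compounds than this note shows. Statements on the series, on what has been measured and on what is new or still open speak of the compounds shown alone.

Compound 1 `COc1ccccc1C(=O)Nc1cccc(NC(=O)c2ccccc2Cl)c1` sits at a limit of an in vitro functional assay on HEK293-A cells for antagonist activity at metabotropic glutamate receptor 5 (Rattus norvegicus), read by calcium flux; on this read-out higher numbers stand for weaker inhibition and lower numbers for stronger inhibition: > 30000 nM.
Compound 2 `COc1ccccc1C(=O)Nc1cccc(NC(=O)c2cc(Cl)cc(Cl)c2)c1` also sits at a limit of this assay: > 30000 nM.
Compound 3 `COc1ccccc1C(=O)Nc1cccc(NC(=O)c2cccc(F)c2)c1` gives a number in this assay: 6480 nM.

Within the data shown here, compound 3 is thus the only compound with a measured number; the other two stand at the limit of > 30000 nM in this assay, at which 2 of the 3 values shown sit. Compound 4 `COc1ccccc1C(=O)Nc1cccc(NC(=O)c2cccc(C#N)c2)c1` differs from compound 3 by cyano in place of fluoro on an aromatic carbon. The measured steps that reach compound 3 are an at least 4.6-fold lower number from compound 1 to compound 3 (0.66 log units; beyond the scatter) and an at least 4.6-fold lower number from compound 2 to compound 3 (0.66 log units; beyond the scatter); both exchange one halogen-bearing phenyl for another, and none of them swaps fluoro for cyano, so they bear on the new change only loosely. Among the measured compounds shown here, no step points in a direction beyond the scatter, and compound 4 is therefore expected to stay near compound 3, with a 1.1-fold lower number from compound 3 to compound 4 (0.03 log units; within the scatter) as the estimated step. The estimate for compound 4 in this assay is 6000 nM, between 1500 nM and 25000 nM.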

Compound 4, half-maximal inhibitory concentration: 1800 nM
Compound 4: middle estimate off by 3.3-fold (0.52 log units), on the high side; the measured number falls inside the stated range.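

In this assay, among these compounds, cyano in place of fluoro on this aromatic carbon gives a 3.6-fold lower number from compound 3 to compound 4 (0.56 log units; beyond the scatter), so this position responds to a group other than a halogen, whereas the earlier compounds carried only halogens here. Against the two chlorinated compounds, the 3-cyanophenyl group gives an at least 16-fold lower number from compound 2 to compound 4 (1.22 log units; beyond the scatter) and an at least 16-fold lower number from compound 1 to compound 4 (1.22 log units; beyond the scatter). Those two steps are open-ended, as each starts from a limit: the limit of > 30000 nM in this assay, at which 2 of the 4 values shown sit.

Going by these compounds, how an amine or a carboxylic acid would fare at this position stays open. So does whether cyano on another carbon of this ring would give a similar step.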